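The source may report more compounds than this note shows. Statements on the series, on what has been measured and on what is new or still open speak of the compounds shown alone.

Compound 1 `O=C(CSc1nnnn1-c1cccc2ccccc12)N/N=C/c1ccc(Cl)cc1`: > 295000 nM in an ADME assay on MT4 cells (Homo sapiens) for cytotoxicity, read by MTT assay (a lower number here means that less compound is tolerated, a higher number that more compound is tolerated), a limit of the assay.
Compound 2 `O=C(CSc1nnnn1-c1cccc2ccccc12)N/N=C/c1ccc(F)cc1`: > 307000 nM in this assay, again a limit.
Compound 3 `COc1ccc(/C=N/NC(=O)CSc2nnnn2-c2cccc3ccccc23)cc1OC`: 191000 nM in this assay.

Compound 3 is the only one of the three with an actual number; the others stop at a limit. Compound 4 `CN(C)c1ccc(/C=N/NC(=O)CSc2nnnn2-c2cccc3ccccc23)cc1` has not yet been measured. The change from compound 3 is 4-(dimethylamino)phenyl in place of 3,4-dimethoxyphenyl on a carbon with a double bond to nitrogen. The two measured steps at this position, an at least 1.5-fold lower number from compound 1 to compound 3 (0.18 log units; that floor lies within the scatter) and an at least 1.6-fold lower number from compound 2 to compound 3 (0.20 log units; that floor lies within the scatter), have floors that lie within the scatter, and the limits the limit of > 295000 nM in this assay, at which 1 of the 3 values shown sits, and the limit of > 307000 nM in this assay, at which 1 of the 3 values shown sits, keep their full size from being read. The exchange of one aryl group for another is therefore expected to move compound 4 hardly beyond the scatter, a 1.2-fold higher number from compound 3 to compound 4 (0.06 log units; within the scatter). Compound 4 is estimated at 220000 nM, between 100000 nM and 450000 nM.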

Compound 4, half-maximal cytotoxic concentration: > 289000 nM
Compound 4 was reported as a limit; the forecaster's own chance of this, stated with the estimate: 40%; middle value at least 1.3-fold (0.11 log units) away from the limit.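

In this assay compound 4 stops at a limit, as compounds 1 and 2 do, so dimethylamino joins chloro and fluoro in giving no exact number, and compound 3 alone goes against this pattern. Going by these compounds alone, the one readable change is an at least 1.5-fold higher number from compound 3 to compound 4 (0.17 log units; that floor lies within the scatter), so this exchange cannot yet be separated from the scatter. On these data alone, the full size of that step stays unknown because compound 4 is reported only as a limit: the limit of > 289000 nM in this assay, at which 1 of the 4 values shown sits. The steps among compounds 1, 2 and 4 cannot be read.

As far as these compounds go, how far compounds 1, 2 and 4 lie beyond their limits remains open. Also open, from the compounds shown here alone, is whether a carboxylic acid or a longer chain in place of dimethylamino would give an exact number.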